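Chloro to Bromo: the Expected Potency of Compound 4

A few compounds are considered here, and "the series" means these few. Any claim that something is new, unique, unknown or untested is made for them only; others in the source may bear on it.

Compound 1 `CC1(C)CC(=O)C=C(Nc2ccc(Cl)cc2Cl)C1` gives 17.6 ug/mL in a functional assay on PBMC cells (Homo sapiens) for inhibition, read by thymidine incorporation, with a stated time of 72 h; a lower number here means a stronger inhibitor, a higher number a weaker inhibitor. Compound 2 `CC1(C)CC(=O)C=C(Nc2ccc(Cl)cc2)C1` gives 15 ug/mL in this assay, the lowest of the two numbers shown, with a 1.2-fold lower number from compound 1 to compound 2 (0.07 log units; within the scatter). Compound 3 `CCCCSC(=S)C1=C(Nc2ccc(Cl)cc2)CC(C)(C)CC1=O` reaches only the assay limit > 50 ug/mL in this assay. That change gives an at least 3.3-fold higher number from compound 2 to compound 3 (0.52 log units; beyond the scatter). Compound 4 `CC1(C)CC(=O)C=C(Nc2ccc(Br)cc2)C1` differs from compound 2 by bromo in place of chloro on an aromatic carbon. The step from compound 1 to compound 2, a change of halogen on an aromatic carbon, stayed within the scatter, while the large step to compound 3 concerns another place and does not bear on this swap. Compound 4 is therefore expected to show a 1.1-fold lower number from compound 2 to compound 4 (0.03 log units; within the scatter). The estimate for compound 4 is 14 ug/mL, within 7 ug/mL to 28 ug/mL.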

Compound 4, half-maximal inhibitory concentration: > 50 ug/mL
Compound 4: no number, only a limit; the forecaster's own chance of this, stated with the estimate: 5%; at least 3.5-fold (0.55 log units) between middle value and limit.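

Bromo in place of chloro on the aromatic carbon para to a large group gives an at least 3.3-fold higher number from compound 2 to compound 4 (0.52 log units; beyond the scatter) in this assay. Among the compounds shown here, compounds 1, 2 and 3 all carry chloro at this place, so only this step shows that the read-out responds to a change of halogen there. Compound 4 gives a limit of the assay and not a number: the limit of > 50 ug/mL in this assay, at which 2 of the 4 values shown sit.

Going by these compounds, how far compound 4 lies past that limit stays open. So does whether fluoro, methoxy or an amine at this place would stay close to compound 2.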